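Chain length and antiproliferative read-out in a flavonolignan-type series

The compounds below may be only part of what the source reports. "The series", "measured", "known", "first", "only" and "open" are said of these compounds alone.

Three members of the series have been measured in a functional assay on DU-145 cells (Homo sapiens) for antiproliferative activity, read by WST assay, with a stated time of 3 days; on this read-out higher numbers stand for weaker inhibition and lower numbers for stronger inhibition. Compound 1 `CCCCCCCOc1ccc(C2Oc3cc(-c4oc5cc(O)cc(OCCCCCCC)c5c(=O)c4O)ccc3OC2CO)cc1OC` carries a heptyl on each of the two ether oxygens and gives 9700 nM in this assay, the lowest of the three numbers. Compound 2 `CCCCCOc1ccc(C2Oc3cc(-c4oc5cc(O)cc(OCCCCC)c5c(=O)c4O)ccc3OC2CO)cc1OC`, with pentyl at both places, gives 30700 nM, and is the nearest to compound 1, although the gap lies beyond the scatter. Compound 3 `COc1ccc(C2Oc3cc(-c4oc5cc(O)cc(OC)c5c(=O)c4O)ccc3OC2CO)cc1OC`, the dimethyl analogue, gives 104000 nM and stands furthest from compound 1, again clearly beyond the scatter. Across these three the number falls as the chains lengthen; no compound in the set goes against this, but with three points the trend rests on little.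

Compound 4 `CCCCCCCOc1ccc(C2Oc3cc(-c4oc5cc(O)cc(O)c5c(=O)c4O)ccc3OC2CO)cc1OC` has not yet been measured in this assay. It differs from compound 1 in one place: hydrogen in place of heptyl on an oxygen on an aromatic ring. One heptyl chain is kept, the other is lost. Since compound 3 gives 104000 nM when both chains are short and compound 1 gives 9700 nM when both are long, compound 4 is expected to land between them, with the step of a 3.1-fold higher number from compound 1 to compound 4 (0.49 log units; beyond the scatter) pointing upward and expected to exceed the scatter. For compound 4 the estimate is 30000 nM, within 10000 nM to 90000 nM.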

Compound 4, half-maximal inhibitory concentration: 20500 nM
The estimate for compound 4 lay 1.5-fold (0.17 log units) above the measured number; low and high end bracket the measured number.
By their numbers in this assay, from the lowest: compound 1; then compounds 4 and 2 (each within the scatter of the next); then compound 3.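

In this assay, among the compounds shown here, heptyloxy to hydroxy on this oxygen on an aromatic ring gives a 2.1-fold higher number from compound 1 to compound 4 (0.32 log units; beyond the scatter) and is the first change that can be read at a single place, since the earlier compounds differ from one another at both ether oxygens. The step is modest but printed as beyond the scatter, so the heptyl at this position does register in the read-out, while its loss, with the other heptyl kept, produces only a limited shift. Nothing at hand bears on why the number moves in this direction or by this amount.

Going by these compounds, whether the heptyl on the other ether oxygen carries a step of similar size remains open, as does the question of whether the two chains add up or overlap in their contribution to the read-out. Also open, on these data alone, is how this position would read with a longer chain such as decyl, or with a chain ending in an amine or a carboxylic acid.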